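Extending a methoxy to a prenyl ether on a cyclopropane hydrazide

The source may report more compounds than this note shows. Statements on the series, on what has been measured and on what is new or still open speak of the compounds shown alone.

Compound 1 `COc1ccc(C2CC2C(=O)NNc2nncc3ccccc23)cc1`: 48000 nM
Compound 2 `CCOc1ccc(C2CC2C(=O)NNC(=O)c2ccncc2)cc1`: "not determined" (no result reported)
Compound 3 `O=C(NNC(=O)C1CC1c1ccc(OC(F)(F)F)cc1)c1ccncc1`: "not determined" (no result reported)

Among the compounds with values here, in a functional assay on OE21 cells (Homo sapiens) for inhibition, read by MTT assay, with a stated time of 72 h (on this read-out lower numbers stand for stronger inhibition and higher numbers for weaker inhibition), compound 1 gives 48000 nM, the only number in this set; compound 2 gives "not determined" (no result reported) and compound 3 gives "not determined" (no result reported), so compound 1 stands alone and no step between measured compounds can be compared. Compound 4 `CC(C)=CCOc1ccc(C2CC2C(=O)NNc2nncc3ccccc23)cc1` differs from compound 1 by 2-methylprop-1-en-1-yl in place of hydrogen on a saturated chain carbon bound to an oxygen on an aromatic ring. Within the data shown here, with no measured step to lean on, a modest gain in inhibition for compound 4 is expected, of a size that barely exceeds the usual scatter, and the estimated step of a 1.9-fold lower number from compound 1 to compound 4 (0.28 log units; within the scatter) reflects that. Compound 4 is thus expected to give about 25000 nM, between 6000 nM and 100000 nM.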

Compound 4, half-maximal inhibitory concentration: 38000 nM
Beside the measured number, compound 4's estimate is 1.5-fold (0.18 log units) below it; the range from low to high includes it.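

In this assay, the step of a 1.3-fold lower number from compound 1 to compound 4 (0.10 log units; within the scatter) comes from exchanging methoxy for (3-methylbut-2-en-1-yl)oxy. The two compounds therefore cannot be told apart on this read-out, and this position accepts the larger group without a clear shift in either direction. No measurement is available to account for this result. Going by these compounds, whether an amine, a carboxylic acid or a longer chain in place of the 3-methylbut-2-en-1-yl group would move the number stays open. Within the data shown here, compound 2 and compound 3 carry no number, so no step to them can be read.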